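Vinyl for ethyl on a styryl side chain

The compounds below may be only part of what the source reports. "The series", "measured", "known", "first", "only" and "open" are said of these compounds alone.

Measured in a functional assay on HUVEC cells (Homo sapiens); a lower number here means that less compound is needed, a higher number that more compound is needed for the effect:
Compound 1 `COC1=C(C)C(=O)/C(=C(O)/C=C/c2ccc(F)cc2)C(=O)C1(C)C`: < 4 ug/mL
Compound 2 `CCc1ccc(/C=C/C(O)=C2/C(=O)C(C)=C(OC)C(C)(C)C2=O)cc1`: < 4 ug/mL

Compound 2 stands only at a limit in this assay, < 4 ug/mL, and no number is known for it. Compound 1 also gives only a limit, < 4 ug/mL. The two compounds therefore share (the limit of < 4 ug/mL in this assay, at which 2 of the 2 values shown sit).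

Compound 3 `C=Cc1ccccc1/C=C/C(O)=C1/C(=O)C(C)=C(OC)C(C)(C)C1=O` is unmeasured and differs from compound 2 by 2-vinylphenyl in place of 4-ethylphenyl on a double-bonded chain carbon bound to a double-bonded chain carbon. Among the measured compounds shown here, the only measured step that bears on this change is a step that the two limits leave unreadable from compound 1 to compound 2, with ethyl in place of fluoro on an aromatic carbon. It offers neither a size nor a direction, so no shift beyond the scatter is expected in this assay. The expected step is a step that the limit leaves unreadable from compound 2 to compound 3. Compound 3 is estimated at 2 ug/mL, with an expected range from 0.5 ug/mL to 6 ug/mL.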

Compound 3, concentration for half-maximal effect: < 1.1 ug/mL
Compound 3: a limit, no number (the forecaster's own chance of this, stated with the estimate: 65%); middle value at least 1.8-fold (0.25 log units) from the limit.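

In this assay compound 3 gives only a limit, < 1.1 ug/mL, and the values of compound 1 and compound 2 are limits too, so no step among these compounds can be read. The compounds shown leave open whether 4-fluorophenyl, 4-ethylphenyl and 2-vinylphenyl differ at all in this read-out, in size or direction.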